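This account rests on a few compounds, and the source may have more. Where it says the series, first, only, none or still open, it means among the compounds named here.

Compound 1 `COc1ccc(C(=O)CSc2nc3c([nH]2)c(=O)n(C)c(=O)n3C)cc1` gives 7600 nM in a functional assay on MCF7 cells (Homo sapiens) for inhibition, read by MTT assay, with a stated time of 48 h; a lower number here means a stronger inhibitor, a higher number a weaker inhibitor. Compound 2 `Cn1c(=O)c2[nH]c(SCC(=O)c3ccc(Cl)cc3)nc2n(C)c1=O` gives 8400 nM in this assay; the change is chloro in place of methoxy on an aromatic carbon and the step is a 1.1-fold higher number from compound 1 to compound 2 (0.04 log units; within the scatter). Compound 3 `COc1ccc(/C(CSc2nc3c([nH]2)c(=O)n(C)c(=O)n3C)=N\O)cc1`, which carries a different core, gives 800 nM in this assay; the difference between the two cores is not broken down here, and the values of compound 3 and compound 1 simply show the lower number for compound 3.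

Compound 4 `Cn1c(=O)c2[nH]c(SC/C(=N/O)c3ccc(Cl)cc3)nc2n(C)c1=O` is not yet measured in this assay. It differs from compound 3 by chloro in place of methoxy on an aromatic carbon, the same change as that from compound 1 to compound 2. For compound 4 the step of a 1.1-fold higher number from compound 3 to compound 4 (0.05 log units; within the scatter) is expected, set beside the earlier one, because a 1.1-fold higher number from compound 1 to compound 2 (0.04 log units; within the scatter) stayed within the scatter. Compound 4 is therefore estimated at 900 nM, with 400 nM to 2000 nM as the expected range in this assay.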

Compound 4, half-maximal inhibitory concentration: 1000 nM
Estimate against measurement, compound 4: 1.1-fold (0.05 log units) below; the measured number falls inside the stated range.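

In this assay the change from 4-methoxyphenyl to 4-chlorophenyl gives a 1.3-fold higher number from compound 3 to compound 4 (0.10 log units; within the scatter) and so leaves the number on the core of compound 3 as unmoved as it was on the core of compound 1. The two steps agree: the same change on two cores in this assay, a 1.1-fold higher number (0.04 log units; within the scatter) from compound 1 to compound 2 and a 1.3-fold higher number (0.10 log units; within the scatter) from compound 3 to compound 4, 1.1-fold (0.05 log units) apart, within the scatter of two such steps. This shows only that, for this one pair of groups on these two cores, the swap can be carried across with no measurable effect on either; it does not show that other groups would carry across in the same way, or that the swap would do so on a further core.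

Open, as far as these compounds go, is whether an amine or a carboxylic acid in place of chloro would leave the number equally unmoved. Also open, from the compounds shown here alone, is what a longer chain between the shared core and the six-membered aromatic ring would do.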